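The compounds below may be only part of what the source reports. "The series", "measured", "known", "first", "only" and "open" are said of these compounds alone.

Working notes on the series.

Within the data shown here, compound 1 `COc1ccc2[nH]cc(/C=C(\C#N)C(=O)c3c[nH]c4ccccc34)c2c1` bears a methoxy on its core; in a functional assay on PC-3 cells (Homo sapiens) for cytotoxicity, read by WST assay, with a stated time of 48 h (a lower number here means a stronger inhibitor, a higher number a weaker inhibitor), compound 1 gives 30500 nM, the only plain number in the set. Compound 3 `N#C/C(=C\c1c[nH]c2cc(F)ccc12)C(=O)c1c[nH]c2ccccc12` is built on a different core, and the difference between the two cores is not broken down here. In this assay compound 3 reaches only the limit of > 50000 nM. Compound 2 `N#C/C(=C\c1c[nH]c2cc(F)ccc12)C(=O)c1c[nH]c2cc(F)ccc12` is derived from compound 3 by fluoro in place of hydrogen on an aromatic carbon. In this assay compound 2 likewise stops at the limit of > 50000 nM. The step that the two limits leave unreadable from compound 3 to compound 2 cannot be sized, because the limit of > 50000 nM in this assay, at which 2 of the 3 values shown sit, hides it.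

Compound 4 `COc1ccc2[nH]cc(/C=C(\C#N)C(=O)c3c[nH]c4cc(F)ccc34)c2c1` is not yet measured in this assay. It is derived from compound 1 by fluoro in place of hydrogen on an aromatic carbon, the same change as between compound 3 and compound 2. No readable step for that change exists in the set, so the expectation for compound 4 rests on compound 1 and its value of 30500 nM, with a step of a 1.1-fold higher number from compound 1 to compound 4 (0.06 log units; within the scatter) expected to stay near the scatter. For compound 4 in this assay the estimated value is 35000 nM, expected between 15000 nM and 90000 nM.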

Compound 4, half-maximal inhibitory concentration: > 50000 nM
Compound 4 ended at the assay's limit; the forecaster's own chance of this, stated with the estimate: 35%; middle value at least 1.4-fold (0.15 log units) away from the limit.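

On the core of compound 1, fluoro in place of hydrogen on an aromatic carbon gives, in this assay, an at least 1.6-fold higher number from compound 1 to compound 4 (0.21 log units; that floor lies within the scatter), so the data show no gain in potency from this change on that core, and the printed floor does not establish a real loss. Compound 4 gives > 50000 nM, which is a limit of the assay and not a number. The same change on the core of compound 3 cannot be read, so nothing shows whether it has a like size on both cores, because all readings there stop at one ceiling: the limit of > 50000 nM in this assay, at which 3 of the 4 values shown sit.

Among these compounds, compound 1 is the only compound here with a plain number, which leaves open how far above that ceiling the other three compounds lie and what separates the two cores. Going by these compounds, it also remains open whether an amine or a carboxylic acid in place of the methoxy of compound 1 would give a lower number in this assay.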